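A Furan Ring Replaces the Trifluoromethylphenyl Group

The compounds below may be only part of what the source reports. "The series", "measured", "known", "first", "only" and "open" are said of these compounds alone.

Compound 1 `COc1cc(CC(O)c2ccc(-c3ccc(C(F)(F)F)cc3)cc2)c([N+](=O)[O-])cc1OC` was tested in an ADME assay on HeLa Rh cells (Homo sapiens) for cytotoxicity, read by microscopy (a lower number here means that less compound is tolerated, a higher number that more compound is tolerated), where compound 1 gives 4100 nM. Two related compounds share its core. Compound 2 `COc1cc(CC(O)c2ccc(-c3ccc(F)cc3)cc2)c([N+](=O)[O-])cc1OC` gives 4500 nM, and compound 3 `COc1cc(CC(O)c2ccc(-c3cccc(F)c3)cc2)c([N+](=O)[O-])cc1OC` gives 7400 nM. Among these three numbers compound 1 holds the lowest, but all three lie close together: there is a 1.1-fold higher number from compound 1 to compound 2 (0.04 log units; within the scatter), a 1.8-fold higher number from compound 1 to compound 3 (0.26 log units; within the scatter) and a 1.6-fold higher number from compound 2 to compound 3 (0.22 log units; within the scatter), each within the scatter of repeated measurements.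

Compound 4 `COc1cc(CC(O)c2ccc(-c3ccoc3)cc2)c([N+](=O)[O-])cc1OC` has not yet been measured. Its structure differs from compound 1 in one place: furan-3-yl in place of 4-(trifluoromethyl)phenyl on an aromatic carbon. The three measured steps each exchange one fluorine-bearing phenyl group for another, and none of them brings in a five-membered aromatic ring with one hetero atom, so they bear on this change only loosely. What they do show is that exchanging the group at this place, in the ways tried, left the tolerated concentration essentially unchanged. Compound 4 is therefore expected to sit near compound 1 as well, with no step beyond the scatter, though the larger structural reach of this change calls for a broad range. For compound 4 the estimated value is 6000 nM, with a range from 2500 nM to 15000 nM. This corresponds to an expected step of a 1.5-fold higher number from compound 1 to compound 4 (0.17 log units; within the scatter).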

Compound 4, half-maximal cytotoxic concentration: 5300 nM
Compound 4: middle estimate off by 1.1-fold (0.05 log units), on the high side, within the range that was stated.
By their numbers in this assay, from the lowest: compounds 1, 2, 4 and 3 (each within the scatter of the next).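

In this assay, furan-3-yl at this place gives a 1.3-fold higher number from compound 1 to compound 4 (0.11 log units; within the scatter) and a 1.2-fold higher number from compound 2 to compound 4 (0.07 log units; within the scatter) and a 1.4-fold lower number from compound 3 to compound 4 (0.14 log units; within the scatter) (so none of the three exchanges leaves the scatter of repeated measurements). The earlier compounds shown here only varied the substituent on a phenyl ring, whereas this change replaces the six-membered aromatic ring of carbon only with a five-membered aromatic ring with one hetero atom, and it removes the fluorine and adds a hydrogen-bond acceptor. The tolerated concentration therefore does not depend, within the scatter, on this place carrying a fluorine-bearing phenyl group or even a six-membered ring, although nothing shown explains why this is so.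

Every group shown at this place is an aromatic ring with no net charge, so it remains open whether an amine, a carboxylic acid or a longer alkyl chain there would give a step beyond the scatter. On these data alone, the nitro group, the two methoxy groups and the hydroxyl group of the shared core stay the same throughout, so their part in the cytotoxicity also remains open.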